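The source may hold more compounds than are shown below. What is called first, only, known or untested is meant among the compounds shown, and "the series" means these compounds.

Measured in a functional assay on HL-60 cells (Homo sapiens) for cytotoxicity, read by MTT assay; a higher number here means a weaker inhibitor, a lower number a stronger inhibitor:
compound 1 `CC(C)C(NS(=O)(=O)c1cccc(Br)c1)C1=CC(=O)c2c(O)ccc(O)c2C1=O`: 790 nM
compound 2 `CC(=O)c1ccc(S(=O)(=O)NC(C2=CC(=O)c3c(O)ccc(O)c3C2=O)C(C)C)cc1`: 110 nM

Of the two, compound 2 has the lower number in this assay, at 110 nM. The next compound is compound 3 `CCOC(=O)c1ccc(S(=O)(=O)NC(C2=CC(=O)c3c(O)ccc(O)c3C2=O)C(C)C)cc1`, which has 4-(ethoxycarbonyl)phenyl in place of the 4-acetylphenyl of compound 2: ethoxy in place of methyl on a carbonyl carbon, (ethoxy in place of methyl on a carbonyl carbon). Among the measured compounds shown here, no measured step tests this change directly. The only one that bears on it is a 7.2-fold lower number from compound 1 to compound 2 (0.86 log units; beyond the scatter), where 4-acetylphenyl replaced 3-bromophenyl on a sulfonyl sulfur. That swap exchanged the whole group, whereas the present change leaves the carbonyl in place. A smaller step is therefore expected in this assay, probably none beyond the scatter, with no firm direction. The expected result is a 1.3-fold higher number from compound 2 to compound 3 (0.10 log units; within the scatter). For compound 3 the estimated value is 140 nM, with an expected range from 45 nM to 420 nM.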

Compound 3, half-maximal inhibitory concentration: 150 nM
The estimate for compound 3 lay 1.1-fold (0.03 log units) below the measured number; measured number inside the range.
By their numbers in this assay, from the lowest: compounds 2 and 3 (each within the scatter of the next); then compound 1.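

In this assay, the change at this carbonyl carbon gave a 1.4-fold higher number from compound 2 to compound 3 (0.13 log units; within the scatter), so ethoxy, with more heavy atoms and a hydrogen-bond acceptor that methyl lacks, left the number within the scatter. The second step, a 5.3-fold lower number from compound 1 to compound 3 (0.72 log units; beyond the scatter), shows that 4-(ethoxycarbonyl)phenyl also differs from 3-bromophenyl beyond the scatter, so among these compounds the lower number against compound 1 does not depend on the acetyl group alone. Nothing measured here explains either step.

From the compounds shown here alone, it remains open whether a carboxylic acid, an amide or a longer chain than ethoxy on this carbonyl carbon would also stay within the scatter. Also open, going by these compounds, is how 4-bromophenyl on the sulfonyl sulfur would compare with 3-bromophenyl and 4-acetylphenyl.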